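Swapping an amino-aryl for a dichlorophenyl on the carbonyl

The source may report more compounds than this note shows. Statements on the series, on what has been measured and on what is new or still open speak of the compounds shown alone.

Three analogues share one core. Compound 1 `COc1cc(Cl)cc(-c2nn(-c3cccc(NC(=O)Nc4cccc(C(F)(F)F)c4)c3)cc2-c2ccncc2)c1` gives 8.08% in a functional assay on A549 cells (Homo sapiens) for inhibition, read by sulforhodamine B assay, with a stated time of 48 h, tested at 10 uM; on this read-out higher numbers stand for a weaker effect at the one concentration tested and lower numbers for a stronger effect; compound 2 `COc1cc(Cl)cc(-c2nn(-c3cccc(NC(=O)Nc4ccc(Cl)c(C(F)(F)F)c4)c3)cc2-c2ccncc2)c1` gives 5.2%, the lowest of the three, while compound 3 `COc1cc(Cl)cc(-c2nn(-c3cccc(NC(=O)c4cc(C(F)(F)F)cc(C(F)(F)F)c4)c3)cc2-c2ccncc2)c1` gives 43.5%. Within the data shown here, the only single-point step known, a number 2.9 percentage points lower from compound 1 to compound 2 (within the scatter), concerns a change elsewhere in the molecule and says nothing about the carbonyl carbon. Compound 4 `COc1cc(Cl)cc(-c2nn(-c3cccc(NC(=O)c4ccc(Cl)c(Cl)c4)c3)cc2-c2ccncc2)c1` arises from compound 2 by the change (3,4-dichlorophenyl in place of (4-chloro-3-(trifluoromethyl)phenyl)amino on a carbonyl carbon). Compound 3 is the nearest guide, since it too carries a carbon ring bonded straight to the carbonyl carbon, and its value stands well beyond the scatter above compound 2. A rise is therefore expected, and compound 4 is estimated at 35%, between 10% and 65%, a step of a number 29.8 percentage points higher from compound 2 to compound 4 (beyond the scatter).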

Compound 4, a percentage reported as activity, at one concentration (the size of the read-out at that concentration, not a potency): 59.7%
Beside the measured number, compound 4's estimate is 24.7 percentage points below it, within the range that was stated.
By their numbers in this assay, from the lowest: compounds 2 and 1 (each within the scatter of the next); then compound 3; then compound 4.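

On the carbonyl carbon, a phenylamino-type group cannot be exchanged for 3,4-dichlorophenyl without a clear loss of effect in this assay: the change gives a number 54.5 percentage points higher from compound 2 to compound 4 (beyond the scatter), and the same kind of change gives a number 51.6 percentage points higher from compound 1 to compound 4 (beyond the scatter). Among these compounds, both steps are large, so this is the first single-place evidence that the group on the carbonyl carbon strongly affects the read-out. No measurement here explains the loss. The compounds shown leave open how a benzylamino or a plain amino group on that carbonyl carbon would behave.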